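Triazole side chain: decyl to hydroxyethyl on the shared core

The source may report more compounds than this note shows. Statements on the series, on what has been measured and on what is new or still open speak of the compounds shown alone.

Two compounds of the series have been run in a functional assay on HCT-116 cells (Homo sapiens) for antiproliferative activity, read by MTT assay, with a stated time of 72 h; on this read-out lower numbers stand for stronger inhibition and higher numbers for weaker inhibition. Compound 1 `CC(C)(C)OC(=O)N1CCN(C(=S)SCc2cn(C[C@H](O)[C@H]3OC(=O)C(OCc4ccccc4)=C3OCc3ccccc3)nn2)CC1` gives only a limit in this assay, > 100000 nM, and no number. For the measured compounds named here, compound 2 `CCCCCCCCCCc1cn(C[C@H](O)[C@H]2OC(=O)C(OCc3ccccc3)=C2OCc2ccccc2)nn1` is the one compound with a measured number, 28800 nM in this assay. Compound 2 thus holds the only number shown. The other result is the limit reached by compound 1 (the limit of > 100000 nM in this assay, at which 1 of the 2 values shown sits).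

Compound 3 `O=C1O[C@H]([C@@H](O)Cn2cc(CCO)nn2)C(OCc2ccccc2)=C1OCc1ccccc1` is not yet measured. It differs from compound 2 by hydroxy in place of octyl on a saturated chain carbon, two bonds along the chain from an aromatic carbon. Going by the values given here, no step between measured compounds is available on which to rest the size of the change. The expectation for this assay is a shift toward a weaker read-out, beyond the scatter, with a fair chance that this assay reports only a limit for compound 3. Compound 3 is estimated at 80000 nM, within 30000 nM to 200000 nM. The step from compound 2 to compound 3 is thus expected to read a 2.8-fold higher number from compound 2 to compound 3 (0.44 log units; beyond the scatter).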

Compound 3, half-maximal inhibitory concentration: 72700 nM
Compound 3: the middle estimate sits 1.1-fold (0.04 log units) above what was measured, and the stated range covers the measured number.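

Going from the decyl chain to 2-hydroxyethyl on the triazole side chain gives the first readable step in the series, and in this assay it is a 2.5-fold higher number from compound 2 to compound 3 (0.40 log units; beyond the scatter). The step is modest, and compound 3 still returns a number rather than a limit, so at this position the long decyl chain is not needed for a number on this read-out. Compound 1 stays a limit, so steps to it cannot be read: the limit of > 100000 nM in this assay, at which 1 of the 3 values shown sits.

This single step changes chain length and adds hydroxy together, so the compounds shown do not separate the two. A plain ethyl chain, a 2-aminoethyl chain or a carboxylic acid on the same side chain, each on the shared core, would show how much of the step belongs to each.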